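The source may report more compounds than this note shows. Statements on the series, on what has been measured and on what is new or still open speak of the compounds shown alone.

Compound 3 `CCS(=O)(=O)Nc1cc(Cl)cc2c1CCCC2c1c[nH]cn1` gives the lowest of the three numbers measured in an assay on isolated protein for binding affinity to Alpha-1A adrenergic receptor (Rattus norvegicus), read by radioligand binding (a higher number here means a weaker inhibitor, a lower number a stronger inhibitor), namely 45.7 nM. Its nearest neighbour is compound 2 `CCS(=O)(=O)Nc1cc(F)cc2c1CCCC2c1c[nH]cn1`, which in this assay gives 83.2 nM; the step from compound 2 to compound 3 a 1.8-fold lower number from compound 2 to compound 3 (0.26 log units; within the scatter) lies within the scatter, so the two are not distinguished. The furthest is compound 1 `CN(c1cccc2c1CCCC2c1c[nH]cn1)S(C)(=O)=O`, which gives 204 nM, a gap beyond the scatter.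

Compound 4 `CCS(=O)(=O)Nc1cc(C2CCCCC2)cc2c1CCCC2c1c[nH]cn1` differs from compound 3 by a single change: cyclohexyl in place of chloro on an aromatic carbon. Going by the values given here, none of the measured steps exchanges a halogen for a cyclohexyl; the only step that touches this aromatic carbon is the fluoro-to-chloro step from compound 2 to compound 3, which was within the scatter. That step gives no footing for a change of this size, so the estimate for compound 4 must rest on compound 3 alone and carry a wide range. In this assay compound 4 is therefore expected to give about 60 nM, between 12 nM and 300 nM, which amounts to an expected step of a 1.3-fold higher number from compound 3 to compound 4 (0.12 log units; within the scatter) not clearly beyond the scatter.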

Compound 4, inhibition constant: 269 nM
Compound 4: middle estimate off by 4.5-fold (0.65 log units), on the low side; measured number inside the range.
By their numbers in this assay, from the lowest: compounds 3 and 2 (each within the scatter of the next); then compounds 1 and 4 (each within the scatter of the next).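

Cyclohexyl on this aromatic carbon gives a 5.9-fold higher number from compound 3 to compound 4 (0.77 log units; beyond the scatter) and a 3.2-fold higher number from compound 2 to compound 4 (0.51 log units; beyond the scatter) in this assay and so shows what the two halogens could not: the group held here can move the number beyond the scatter. The rise is modest in both steps, so this position accepts a ring of six carbons in place of a single halogen atom and binding is still measured. No measurement given here explains the rise.

A single cyclohexyl compound cannot separate the effect of the number of atoms from that of the ring itself, and a methyl, an isopropyl or a phenyl group on this carbon would bear on that. From the compounds shown here alone, whether an amine or a carboxylic acid would be accepted at this position also remains open.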